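The source may hold more compounds than are shown below. What is called first, only, known or untested is meant among the compounds shown, and "the series" means these compounds.

In a functional assay on HBL-100 cells (Homo sapiens) for inhibition, read by sulforhodamine B assay, with a stated time of 48 h (a lower number here means a stronger inhibitor of growth, a higher number a weaker inhibitor of growth), the three measured compounds gave these numbers:

Compound 1 `O=C(/C=C/c1ccc(Cl)cc1Cl)c1ccccc1`: 17000 nM
Compound 2 `O=C(/C(=C/c1ccccc1)CCl)c1ccccc1`: 12000 nM
Compound 3 `CC(=O)OC/C(=C\c1ccccc1)C(=O)c1ccccc1`: 17000 nM

Compound 3 and compound 1 give the same number at the digits shown, and compound 2 differs from compound 3 only by a 1.4-fold higher number from compound 2 to compound 3 (0.15 log units; within the scatter), so all three lie within the scatter of one another; none can be called stronger or weaker than the others.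

Compound 4 `CC(=O)OC/C(=C\c1ccccc1F)C(=O)c1ccccc1` has not been measured in this assay. It differs from compound 3 by fluoro in place of hydrogen on an aromatic carbon. Within the data shown here, the only measured step, a 1.4-fold higher number from compound 2 to compound 3 (0.15 log units; within the scatter), concerns the chain and not the aromatic ring, so no measured step bears on a change at a ring carbon; the data give no guide to the size or direction of this change. With nothing to suggest otherwise, the step of no change at the digits printed from compound 3 to compound 4 (within the scatter) is expected to stay within the scatter. Compound 4 is therefore estimated at 17000 nM, with a range from 8000 nM to 36000 nM.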

Compound 4, concentration for 50% growth inhibition: 17000 nM
Beside the measured number, compound 4's estimate shows no gap at the digits printed; measured number inside the range.
By their numbers in this assay, from the lowest: compounds 2, 1, 3 and 4 (each within the scatter of the next).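

Among these compounds, measured in this assay and with fluoro in place of hydrogen on an aromatic carbon, ortho to a large group, the ring shows no change at the digits printed from compound 3 to compound 4 (within the scatter) and so gives the first reading of a change on the ring instead of the chain. For this one pair, going from phenyl to 2-fluorophenyl leaves the number where it was, so this position takes a single fluorine atom with no change that can be told from the scatter. No measurement of any other kind bears on this result.

On these data alone, whether fluoro on other carbons of the ring would behave alike stays open, as does whether a different group here, such as methoxy, an amine or a carboxylic acid, would hold the number. Also open, as far as these compounds go, is whether the same fluoro would leave the number alone with chloro instead of acetoxy on the chain, as in compound 2.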